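Thiazolidinedione aryl ethers: swapping chloro for trifluoromethyl

The compounds below may be only part of what the source reports. "The series", "measured", "known", "first", "only" and "open" are said of these compounds alone.

Two measured compounds frame the step. Compound 1 `O=C1NC(=O)C(Cc2ccc(Oc3ncc(Cl)cc3Cl)cc2)S1` and compound 2 `O=C1NC(=O)C(Cc2ccc(Oc3cccc(Cl)c3)cc2)S1` share the same core and differ in the second aromatic ring and its substituents. In a functional assay for agonist activity at Free fatty acid receptor 1 (Homo sapiens), read by FLIPR, in the presence of a further agent that is not named here (on this read-out higher numbers stand for an effect only at larger amounts of compound and lower numbers for an effect already at smaller amounts), compound 1 gives 90 nM, and in this assay compound 2 gives 318 nM. Compound 1 therefore has the lowest of the two numbers, and the gap to compound 2 lies beyond the usual scatter, so the two values are ordered rather than equivalent.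

Compound 3 `O=C1NC(=O)C(Cc2ccc(Oc3ncc(C(F)(F)F)cc3Cl)cc2)S1` has not yet been measured. Relative to compound 1 the change is trifluoromethyl in place of chloro on an aromatic carbon; the other chloro group and the aryl ether are kept. Within the data shown here, no measured pair shows this exact change, so no step can be read from the data. The expectation is a small step, with the number for compound 3 moving little or slightly downward, plausibly within the scatter; the expected step is a 1.3-fold lower number from compound 1 to compound 3 (0.11 log units; within the scatter). For compound 3 in this assay the estimate is 70 nM, expected to fall between 30 nM and 200 nM.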

Compound 3, half-maximal effective concentration: 69 nM
For compound 3 the middle estimate is 1.0-fold (0.01 log units) above the measured one; measured number inside the range.
By their numbers in this assay, from the lowest: compounds 3 and 1 (each within the scatter of the next); then compound 2.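

In this assay, the position two atoms from the ring nitrogen and para to a large group takes trifluoromethyl in place of chloro with a 1.3-fold lower number from compound 1 to compound 3 (0.12 log units; within the scatter). The entering group has 4 heavy atoms against 1 for the group that leaves, so at this position, in this pair, the larger group brings no step beyond the scatter; compound 1 and compound 2 differ in more than one place and could not show this. No accompanying evidence bears on this result.

Going by these compounds, what a nitrile, an amine or a longer chain would give at this same position remains open. Also open, on these data alone, is what the chloro group meta to this position contributes, since compound 1 and compound 3 both carry it.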